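The source may report more compounds than this note shows. Statements on the series, on what has been measured and on what is new or still open speak of the compounds shown alone.

Compound 1 `CC(=O)N1N=C(Nc2nc3ccc(C)cc3s2)CC1c1ccc(Cl)cc1` and compound 2 `CC(=O)N1N=C(Nc2nc3ccc(Cl)cc3s2)CC1c1ccc(Cl)cc1` share one core and differ only at a single ring position. In a functional assay on the whole organism (Hindlimb, strain albino) with Mus musculus as the target, in the maximal electroshock model, with a stated time of 0.5 h (on this read-out lower numbers stand for an effect already at smaller amounts and higher numbers for an effect only at larger amounts of compound), compound 1 gives 25.5 umol/kg, while compound 2 gives 79.5 umol/kg. The change between them is methyl in place of chloro on an aromatic carbon, and it produced a 3.1-fold lower number from compound 2 to compound 1 (0.49 log units; beyond the scatter).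

Compound 3 `COc1ccc(/C=C/C(=O)Nc2nc3ccc(Cl)cc3s2)cc1O` carries a different core; how it differs from the core of compound 2 is not broken down here. In this assay compound 3 gives 320 umol/kg, the highest of the three numbers, and its steps to compound 2 and to compound 1 both lie beyond the scatter.

Compound 4 `COc1ccc(/C=C/C(=O)Nc2nc3ccc(C)cc3s2)cc1O` stands to compound 3 as compound 1 stands to compound 2: the change is methyl in place of chloro on an aromatic carbon, the same change seen in the pair compound 2 to compound 1, at the same place on the two-ring system. Whether it carries over from one core to the other is the open point, since the pairing has been seen only once.

On the basis of compound 1 and compound 2, where the change gave a 3.1-fold lower number from compound 2 to compound 1 (0.49 log units; beyond the scatter), a lower number is expected for compound 4, and the step from compound 3 to compound 4 is estimated as a 2.5-fold lower number from compound 3 to compound 4 (0.39 log units; beyond the scatter). Compound 4 is therefore expected to give about 130 umol/kg in this assay, most likely between 50 umol/kg and 350 umol/kg.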

Compound 4, dose for half-maximal effect: 271 umol/kg
Beside the measured number, compound 4's estimate is 2.1-fold (0.32 log units) below it; measured number inside the range.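

On the second core, methyl in place of chloro on an aromatic carbon gave a 1.2-fold lower number from compound 3 to compound 4 (0.07 log units; within the scatter) in this assay, so on this core the exchange left the number within the usual scatter, whereas on the first core the step, a 3.1-fold lower number from compound 2 to compound 1 (0.49 log units; beyond the scatter), lay beyond it. Set side by side, the two steps cannot be told apart, even though only one of them stands clear of the scatter on its own: the same change on two cores in this assay, a 3.1-fold lower number (0.49 log units; beyond the scatter) from compound 2 to compound 1 and a 1.2-fold lower number (0.07 log units; within the scatter) from compound 3 to compound 4, 2.6-fold (0.42 log units) apart, within the scatter of two such steps

This shows that the two pairs are compatible with a single shared effect of the exchange, and equally with a small effect or none on the second core, but it does not show that the change carries over from one core to the other, since two pairs cannot decide between these readings.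

The compounds shown leave open how other groups on that aromatic carbon, such as fluoro, methoxy or an amine, would read in this assay on either core. They also leave open whether a third core would follow the step seen on the first core or the one seen on the second.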